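Swapping the benzylamine aryl in a bis(trifluoromethyl)sulfonamide series

The compounds below may be only part of what the source reports. "The series", "measured", "known", "first", "only" and "open" are said of these compounds alone.

Measured compounds: compound 1 `CN(CCCNS(=O)(=O)c1cc(C(F)(F)F)cc(C(F)(F)F)c1)Cc1ccccc1` with 51000 nM; compound 2 `O=S(=O)(NCCCNCc1cccc2ccccc12)c1cc(C(F)(F)F)cc(C(F)(F)F)c1` with 21000 nM; compound 3 `COc1ccc(CNCCCNS(=O)(=O)c2cc(C(F)(F)F)cc(C(F)(F)F)c2)cc1` with 2800 nM, all in a functional assay on ASPC1 cells (Homo sapiens) for inhibition, read by MTT assay, with a stated time of 72 h; a higher number here means a weaker inhibitor of growth, a lower number a stronger inhibitor of growth.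

Compound 3 gives the lowest number of the three, a step of a 7.5-fold lower number from compound 2 to compound 3 (0.88 log units; beyond the scatter) and a step of an 18-fold lower number from compound 1 to compound 3 (1.26 log units; beyond the scatter). Compound 4 `O=S(=O)(NCCCNCc1cccc(Cl)c1)c1cc(C(F)(F)F)cc(C(F)(F)F)c1` carries the change (3-chlorophenyl in place of 4-methoxyphenyl on a saturated chain carbon bound to an amine nitrogen). The step that bears on it is the change of the aryl at the same place, a 7.5-fold lower number from compound 2 to compound 3 (0.88 log units; beyond the scatter), which was modest; the other step also altered the amine and cannot be separated. Both variations of this aryl moved the number in this assay well beyond the scatter, so for compound 4 a modest rise is expected, estimated at 5500 nM within 1500 nM to 20000 nM, a step of a 2.0-fold higher number from compound 3 to compound 4 (0.29 log units; within the scatter).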

Compound 4, concentration for 50% growth inhibition: 5900 nM
Estimate against measurement, compound 4: 1.1-fold (0.03 log units) below; low and high end bracket the measured number.
By their numbers in this assay, from the lowest: compound 3; then compound 4; then compound 2; then compound 1.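

In this assay the 3-chlorophenyl group falls short of 4-methoxyphenyl but improves on naphthalen-1-yl at this place, with a 2.1-fold higher number from compound 3 to compound 4 (0.32 log units; beyond the scatter) and a 3.6-fold lower number from compound 2 to compound 4 (0.55 log units; beyond the scatter) showing that the aryl can lose the methoxy oxygen and still keep much of the gain over compound 2. The (3-chlorobenzyl)amino group also shows an 8.6-fold lower number from compound 1 to compound 4 (0.94 log units; beyond the scatter) but that step changes the amine as well as the aryl. Left open is whether the substituent or its ring place sets the gap between compound 3 and compound 4: 4-chlorophenyl or 3-methoxyphenyl would separate the two, and a plain benzylamino group would isolate the methyl on the amine. Nothing available explains these differences.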